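The source may report more compounds than this note shows. Statements on the series, on what has been measured and on what is new or still open speak of the compounds shown alone.

Measured so far:
- compound 1, `CCn1nc(-c2cccs2)c2sccc2c1=O`: 1%
- compound 2, `CCc1nn(CC)c(=O)c2ccsc12`: 14%

Both compounds were run in an assay on CHO cells for displacement of a labelled ligand from adenosine receptor A3 (Homo sapiens), read by scintillation counting, with a stated time of 120 min, tested at 1 uM; a higher number here means more inhibition at the concentration tested (going by the name of the read-out), a lower number less inhibition. Going by the values given here, compound 2 gives 14%, the higher of the two numbers; its nearest neighbour is compound 1 with 1%, and the only step in hand, a number 13 percentage points higher from compound 1 to compound 2 (beyond the scatter), is a modest one beyond the scatter.

Compound 3 is `CCc1nn(CC)c(=O)c2cc(-c3ccccc3)sc12`. It differs from compound 2 in one place: phenyl in place of hydrogen on an aromatic carbon.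

Among the compounds with values here, no measured step concerns a change at this place. Within the data shown here, the one step known, a number 13 percentage points higher from compound 1 to compound 2 (beyond the scatter), removes an aryl ring elsewhere on the core and exchanges it for a chain; it does not tell how a phenyl entering on the ring carbon of compound 2 will read in this assay. What the two values show is that the aryl-bearing compound 1 sits lower than compound 2, but that is a different position and a different ring. The expectation for compound 3 is therefore held near compound 2, with a wide range and no clear direction; a step of about a number 4 percentage points higher from compound 2 to compound 3 (within the scatter) is expected, which is within the scatter. For compound 3 the estimate in this assay is 18%, between 0% and 45%.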

Compound 3, a percentage reported as inhibition, at one concentration (the size of the read-out at that concentration, not a potency): 10%
Beside the measured number, compound 3's estimate is 8 percentage points above it, within the range that was stated.
By their numbers in this assay, from the lowest: compounds 1, 3 and 2 (each within the scatter of the next, the first and the last beyond it).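

In this assay, going by these compounds alone, the entry of phenyl in place of hydrogen on an aromatic carbon, next to the ring sulfur, gives a number 4 percentage points lower from compound 2 to compound 3 (within the scatter) and is the first reading at this place on the shared core. Compound 3 at 10% cannot be told apart from compound 2 in this read-out: a six-membered aromatic ring of carbon only, set at this place, moves the number neither up nor down beyond the scatter. Nothing on hand accounts for this reading.

Open, going by these compounds, is whether another group at this place, such as an amine, a carboxylic acid, a longer chain or a phenyl carrying a substituent of its own, would shift the number beyond the scatter in either direction. Also open, on these data alone, is whether the phenyl reads the same way when thiophen-2-yl replaces the ethyl on the aromatic carbon, as on the core of compound 1, and whether any of these readings at a single concentration would hold as a potency.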